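Amide-linked aminoacetyl variants on two benzophenone-type cores

The compounds below may be only part of what the source reports. "The series", "measured", "known", "first", "only" and "open" are said of these compounds alone.

Compound 1, `CCNCC(=O)Nc1cc(OC)ccc1C(=O)c1ccc2c(c1)C=CC(C)(C)O2`: 1300 nM
Compound 2, `COc1ccc(C(=O)c2ccc3c(c2)C=CC(C)(C)O3)c(NC(=O)CN(C)C)c1`: 1160 nM
Compound 3, `CCNCC(=O)Nc1cc(OC)ccc1C(=O)c1cc(OC)c(OC)c(OC)c1`: 750 nM

Of the compounds shown here, three have been measured in a functional assay on A549 cells (Homo sapiens) for antiproliferative activity, read by MTT assay, with a stated time of 48 h; on this read-out higher numbers stand for weaker inhibition and lower numbers for stronger inhibition. Compound 1 gives 1300 nM and compound 2 gives 1160 nM; the two share one core and differ only by dimethylamino in place of ethylamino on a saturated chain carbon bound to a carbonyl carbon. That change gave a 1.1-fold lower number from compound 1 to compound 2 (0.05 log units; within the scatter). Compound 3 carries a different core; the difference between the two cores is not broken down here. In this assay compound 3 gives 750 nM, which sits within the scatter of the other two values, so no order among the three can be read from these numbers.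

Compound 4, `COc1ccc(C(=O)c2cc(OC)c(OC)c(OC)c2)c(NC(=O)CN(C)C)c1`, is not yet measured. It differs from compound 3 by dimethylamino in place of ethylamino on a saturated chain carbon bound to a carbonyl carbon, the same change that separates compound 1 from compound 2, made at the same place. Because that earlier change gave a 1.1-fold lower number from compound 1 to compound 2 (0.05 log units; within the scatter), the step from compound 3 to compound 4 is expected to be of similar size, namely a 1.1-fold lower number from compound 3 to compound 4 (0.03 log units; within the scatter). Compound 4 is therefore estimated at 700 nM in this assay, with a likely range from 350 nM to 1400 nM.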

Compound 4, half-maximal inhibitory concentration: 590 nM
Compound 4: middle estimate off by 1.2-fold (0.07 log units), on the high side, within the range that was stated.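

Placing dimethylamino where ethylamino stood on the second core gave a 1.3-fold lower number from compound 3 to compound 4 (0.10 log units; within the scatter), and the two steps on the two cores do not differ from each other: the same change on two cores in this assay, a 1.1-fold lower number (0.05 log units; within the scatter) from compound 1 to compound 2 and a 1.3-fold lower number (0.10 log units; within the scatter) from compound 3 to compound 4, 1.1-fold (0.05 log units) apart, within the scatter of two such steps

So in this assay, this change carried from one core to the other without any step standing out from the scatter, which means the two pairs agree in showing no effect that can be told apart from repeat-to-repeat noise. This does not show that dimethylamino truly improves on ethylamino, and two cores are too few to say that the change would behave the same way on any other core.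

The compounds shown leave open what happens at this place with a clearly different group, such as a plain amino group, a diethylamino group or a carboxylic acid. They also leave open whether a longer chain between the carbonyl and the amine would move the values beyond the scatter.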